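A few compounds are considered here, and "the series" means these few. Any claim that something is new, unique, unknown or untested is made for them only; others in the source may bear on it.

Measured so far:

- Compound 1, `CCCCOC(=O)Nc1ccc([Se]C#N)cc1`: in a functional assay on CCRF-CEM cells (Homo sapiens) for cytotoxicity, read by MTT assay, with a stated time of 72 h (a higher number here means a weaker inhibitor of growth, a lower number a stronger inhibitor of growth), compound 1 gives 6500 nM
- Compound 2, `N#C[Se]c1ccc(NC(=O)Oc2ccc(F)cc2)cc1`: compound 2 gives 12600 nM
- Compound 3, `O=C(Nc1ccc([Se][Se]c2ccc(NC(=O)Oc3ccc(F)cc3)cc2)cc1)Oc1ccc(F)cc1`: compound 3 gives 8700 nM

Among these three numbers compound 2 carries the highest one, but the gap to compound 3 and the gap to compound 1 both lie within the usual scatter of repeated measurements, so the three compounds cannot be placed in any order on this evidence.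

The next compound, compound 4, `N#C[Se]c1ccc(NC(=O)Oc2ccc(Cl)cc2)cc1`, differs from compound 2 in one place: chloro in place of fluoro on an aromatic carbon. Going by the values given here, no pair of already measured compounds shows what this exchange does in this assay, so there is no measured step to lean on. Given that the three measured numbers sit so close together, the expectation is a step from compound 2 to compound 4 that stays within the scatter, with at most a slight lean toward a lower number, and no change beyond the scatter is predicted.

On that basis the estimate for compound 4 in this assay is 10000 nM, within a range from 4000 nM to 25000 nM, which corresponds to an expected step of a 1.3-fold lower number from compound 2 to compound 4 (0.10 log units; within the scatter).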

Compound 4, concentration for 50% growth inhibition: 18300 nM
Compound 4: the middle estimate sits 1.8-fold (0.26 log units) below what was measured; the measured number falls inside the stated range.
By their numbers in this assay, from the lowest: compounds 1, 3, 2 and 4 (each within the scatter of the next, the first and the last beyond it).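

In this assay the exchange of fluoro for chloro, on an aromatic carbon para to a large group, gives a 1.5-fold higher number from compound 2 to compound 4 (0.16 log units; within the scatter) and so stays within the scatter of repeated measurements. This is the only pair among the compounds shown that differs in one place, which makes it the first direct reading of this position: swapping one of these two halogens for the other leaves no change that can be told apart from the noise of the assay, though a single pair cannot show that the position is insensitive in general. No measurement shown here bears on what lies behind this result.

Going by these compounds alone, it remains open whether a group of another kind at this same position, such as an amine, a carboxylic acid or a longer chain, would shift the number beyond the scatter, as fluoro and chloro are the only two groups seen there. Within the data shown here, also open is how much each other part of the molecule contributes, as no other pair of compounds here differs in only one place.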